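The source may report more compounds than this note shows. Statements on the series, on what has been measured and on what is new or still open speak of the compounds shown alone.

Compound 1 `Cc1ccc(CN2CC=C(CCC(=O)NO)C2=O)cc1`, compound 2 `O=C(CCC1=CCN(Cc2ccc(F)cc2)C1=O)NO` and compound 3 `O=C(CCC1=CCN(Cc2cccc(Cl)c2)C1=O)NO` share one core and differ only in the group on the aromatic ring attached through the benzylic linker. In a functional assay on NCI-H23 cells (Homo sapiens) for inhibition, read by sulforhodamine B assay (a lower number here means a stronger inhibitor of growth, a higher number a weaker inhibitor of growth), compound 1 gives 2500 nM, compound 2 gives 4670 nM and compound 3 gives 2500 nM. Compound 2 stands with both other numbers inside the usual scatter of its own, so the three compounds cannot be told apart on these data.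

Compound 4 `O=C(CCC1=CCN(Cc2ccc(Cl)cc2)C1=O)NO` arises from compound 2 by a single exchange: chloro in place of fluoro on an aromatic carbon.

Within the data shown here, only one measured step touches this part of the molecule, the one from compound 1 to compound 2, where fluoro replaced methyl and the number moved by a 1.9-fold higher number from compound 1 to compound 2 (0.27 log units; within the scatter), a change within the scatter. Compound 3 also carries a chloro on its aromatic ring, and its number sits within the scatter of compound 2. Nothing measured here shows a halogen exchange at this position producing a shift beyond the scatter, so the step in this assay for compound 4 is expected to be small, a 1.6-fold lower number from compound 2 to compound 4 (0.19 log units; within the scatter), with no direction that can be trusted.

The estimate for compound 4 in this assay is therefore 3000 nM, expected to fall between 1400 nM and 6500 nM.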

Compound 4, concentration for 50% growth inhibition: 2500 nM
Compound 4: the middle estimate sits 1.2-fold (0.08 log units) above what was measured; low and high end bracket the measured number.
By their numbers in this assay, from the lowest: compounds 1, 3, 4 and 2 (each within the scatter of the next).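

Placing chloro instead of fluoro on the aromatic carbon para to a large group gives a 1.9-fold lower number from compound 2 to compound 4 (0.27 log units; within the scatter) in this assay, while placing chloro instead of methyl there gives no change at the digits printed from compound 1 to compound 4 (within the scatter). Methyl, fluoro and chloro at this position therefore cannot be told apart in this assay, and this now includes a direct comparison of chloro with each of the other two groups; compound 3, which carries its chloro elsewhere on the ring, gives 2500 nM, and compound 4 gives 2500 nM, so the printed values offer no sign that the location of the chloro matters. Nothing available here explains why these exchanges leave the numbers so close.

As far as these compounds go, all four compounds carry a single small group on this ring, so it remains open whether a group of a different kind at this position, such as an amine, a carboxylic acid or a methoxy group, would move the number beyond the scatter. Among these compounds, it is equally open how growth inhibition would respond to changes elsewhere in the molecule, such as a longer chain in place of the one all four compounds share.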